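A few compounds are considered here, and "the series" means these few. Any claim that something is new, unique, unknown or untested is made for them only; others in the source may bear on it.

In an assay for activation of potassium voltage-gated channel subfamily KQT member 1 (Cavia porcellus) (a higher number here means a weaker inhibitor, a lower number a stronger inhibitor), compound 3, `CCCCCCOc1ccc(C(=O)NCCC(C)(C)C)cc1`, gives 250 nM. Compound 2, `CCCCCCOc1ccc(C(=O)NCCN(CC)CC)cc1`, gives 3500 nM. Compound 1, `CCCCCCOc1ccc(C(=O)NC2CCCC2(C)C)cc1`, gives only a limit of this assay, > 30000 nM.

Compound 3 thus holds the lowest of the two numbers in hand, the step of a 14-fold lower number from compound 2 to compound 3 (1.15 log units; beyond the scatter) separating it from its nearest neighbour, while the move from the limit of compound 1 appears as an at least 120-fold lower number from compound 1 to compound 3 (2.07 log units; beyond the scatter). Compound 4, `CCCCCCOc1ccc(C(=O)NC2CCC(C)(C)C2)cc1`, differs from compound 3 by 3,3-dimethylcyclopentyl in place of 3,3-dimethylbutyl on an amide-type nitrogen. Among the compounds with values here, only the step from compound 1 to compound 3 bears directly on this change, since it also exchanged a dimethylcyclopentyl against the open 3,3-dimethylbutyl chain; yet compound 1 carries a 2,2-dimethylcyclopentyl and compound 4 a 3,3-dimethylcyclopentyl, so that large step is at best a partial guide. Closing the chain into a ring is therefore expected to cost some potency, but less than compound 1 lost, an expected step of a 4.0-fold higher number from compound 3 to compound 4 (0.60 log units; beyond the scatter). Compound 4 is estimated at 1000 nM, expected to lie between 250 nM and 8000 nM.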

Compound 4, half-maximal inhibitory concentration: 360 nM
Estimate against measurement, compound 4: 2.8-fold (0.44 log units) above, and the stated range covers the measured number.
By their numbers in this assay, from the lowest: compounds 3 and 4 (each within the scatter of the next); then compound 2. At a limit, above all of these: compound 1.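

In this assay, the ring and the open chain on the amide-type nitrogen cannot be told apart, a 1.4-fold higher number from compound 3 to compound 4 (0.16 log units; within the scatter), while the 3,3-dimethylcyclopentyl stands clearly ahead of the 2-(diethylamino)ethyl group, a 9.7-fold lower number from compound 2 to compound 4 (0.99 log units; beyond the scatter). Closing the chain into a ring is therefore tolerated here, and the ring as such does not account for the gap between the two dimethylcyclopentyl groups, an at least 83-fold lower number from compound 1 to compound 4 (1.92 log units; beyond the scatter), which shows that the 2,2-dimethylcyclopentyl and 3,3-dimethylcyclopentyl groups are not interchangeable at this position. The value of compound 1 is a limit, so the true size of that gap remains unknown: the limit of > 30000 nM in this assay, at which 1 of the 4 values shown sits.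

On these data alone, whether an unsubstituted cyclopentyl or a cyclohexyl would match the 3,3-dimethylcyclopentyl remains open. So does whether a hydroxyl or an amine on that ring would be tolerated.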